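Amino for chloro on the purine-like core of compound 1

The compounds below may be only part of what the source reports. "The series", "measured", "known", "first", "only" and "open" are said of these compounds alone.

Measured compounds:
compound 1 `ClCc1cccc(Cn2cnc3c(Cl)nc(Cl)nc32)c1` — 1580 nM
compound 2 `ClCc1cccc(Cn2cnc3nc(Cl)nc(Cl)c32)c1` — 140 nM

For the measured compounds named here, in a functional assay on DU-145 cells (Homo sapiens) for cytotoxicity, read by sulforhodamine B assay, with a stated time of 48 h (a higher number here means a weaker inhibitor of growth, a lower number a stronger inhibitor of growth), compound 1 gives 1580 nM, the highest of the two numbers so far. Going by the values given here, compound 2, which has the same groups arranged differently on the shared core, gives 140 nM in this assay, and the gap between the two lies beyond the scatter; no step between them is counted here, so only the two values themselves can be compared.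

Compound 3 `Nc1nc(Cl)c2ncn(Cc3cccc(CCl)c3)c2n1` is not yet measured. It differs from compound 1 by amino in place of chloro on an aromatic carbon. Among the compounds with values here, no measured pair carries this change, so its direction cannot be read from the series. Because compound 1 already stands at 1580 nM, a step of modest size is expected, with a slightly higher number somewhat more likely than a lower one, and it may not clear the scatter. The step from compound 1 to compound 3 is expected to be a 1.6-fold higher number from compound 1 to compound 3 (0.20 log units; within the scatter). Compound 3 is estimated at 2500 nM in this assay, within a range of 600 nM to 10000 nM.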

Compound 3, concentration for 50% growth inhibition: 4260 nM
Beside the measured number, compound 3's estimate is 1.7-fold (0.23 log units) below it; the measured number falls inside the stated range.
By their numbers in this assay, from the lowest: compound 2; then compound 1; then compound 3.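

In this assay, for the compounds shown here, amino in place of chloro on an aromatic carbon between two ring nitrogen atoms gives a 2.7-fold higher number from compound 1 to compound 3 (0.43 log units; beyond the scatter), the first single-place step. This position therefore responds to substitution: replacing this chloro group makes compound 3 a weaker inhibitor of growth than compound 1, and the step lies beyond the scatter, though it remains modest. The structures show that the change brings in a hydrogen-bond donor and a hydrogen-bond acceptor without adding a ring or a net charge, but no measurement available here bears on why the number rises.

A single pair cannot show whether the rise follows from the amino group itself or from the loss of the chloro group, and a methoxy group, a methylamino group or plain hydrogen at this position would help separate the two. As far as these compounds go, it also remains open whether amino for chloro would give a similar step at the remaining chloro group on the core, or on the arrangement of groups found in compound 2.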